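The compounds below may be only part of what the source reports. "The series", "measured", "known", "first", "only" and "open" are said of these compounds alone.

Compounds measured so far in a functional assay on SK-HEP1 cells (Homo sapiens) for cytotoxicity, read by sulforhodamine B assay, with a stated time of 72 h (on this read-out lower numbers stand for stronger inhibition and higher numbers for weaker inhibition), are:

- compound 1 `CCS(=O)(=O)Nc1cc(-c2ccc3ncnc(Nc4ccc(OC)c(Cl)c4)c3c2)cnc1OC` gives 2810 nM
- compound 2 `CCS(=O)(=O)Nc1cc(-c2ccc3ncnc(Nc4ccc(OCc5ccc(F)cc5)c(Cl)c4)c3c2)cnc1OC` gives 1950 nM
- compound 3 `CCCCS(=O)(=O)Nc1cc(-c2ccc3ncnc(Nc4ccc(F)c(Cl)c4)c3c2)cnc1OC` gives 53800 nM

Compound 1 sits level with compound 2 within the scatter, while compound 3 shows a far higher number. Compound 4 `CCS(=O)(=O)Nc1cc(-c2ccc3ncnc(Nc4ccc(OC)nc4)c3c2)cnc1OC` is not yet measured and differs from compound 1 in one place: 6-methoxypyridin-3-yl in place of 3-chloro-4-methoxyphenyl on a nitrogen on an aromatic ring and the core stays the same. Going by the values given here, the only measured step, a 1.4-fold lower number from compound 1 to compound 2 (0.16 log units; within the scatter), does not replace this ring, so it bears only loosely, and no measured step makes this exact swap. The expected step is a 1.8-fold higher number from compound 1 to compound 4 (0.25 log units; within the scatter) in this assay as a modest rise in the number, though it may not clear the scatter. Compound 4 is estimated at 5000 nM with an expected range from 1200 nM to 20000 nM for now.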

Compound 4, half-maximal inhibitory concentration: 3440 nM
Beside the measured number, compound 4's estimate is 1.5-fold (0.16 log units) above it, within the range that was stated.
By their numbers in this assay, from the lowest: compounds 2, 1 and 4 (each within the scatter of the next); then compound 3.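

In this assay, the step with 6-methoxypyridin-3-yl in place of 3-chloro-4-methoxyphenyl is a 1.2-fold higher number from compound 1 to compound 4 (0.09 log units; within the scatter). This is the first step shown that replaces the whole ring on this nitrogen, and it shows that a ring with one hetero atom and no chlorine leaves the number level with that of compound 1. No evidence is available on why the two rings read alike. Still open, as far as these compounds go, is whether this level reading would hold with an amine or a carboxylic acid on the pyridine ring in place of the methoxy group.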